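Nitro in Place of Bromo: A Small Step Expected

The source may hold more compounds than are shown below. What is called first, only, known or untested is meant among the compounds shown, and "the series" means these compounds.

In a functional assay on L1210 cells (Mus musculus) for antiproliferative activity (a higher number here means a weaker inhibitor, a lower number a stronger inhibitor), compound 1 `C=C1C(=O)ON(C)C1c1ccc(C)cc1` gives 800 nM, and compound 2 `C=C1C(=O)ON(C)C1c1ccc(Br)cc1` gives 700 nM. Compound 2 thus holds the lower of the two numbers, yet compound 1 sits within the scatter of it. For the measured compounds named here, the single measured step, a 1.1-fold lower number from compound 1 to compound 2 (0.06 log units; within the scatter), swapped one aromatic substituent and stayed within the scatter. Compound 3 `C=C1C(=O)ON(C)C1c1ccc([N+](=O)[O-])cc1` differs from compound 2 by nitro in place of bromo on an aromatic carbon. On that basis a step of a 1.1-fold lower number from compound 2 to compound 3 (0.03 log units; within the scatter) is expected, nothing beyond the scatter. Compound 3 is therefore estimated at 650 nM, in the range 250 nM to 1600 nM.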

Compound 3, half-maximal inhibitory concentration: 800 nM
The estimate for compound 3 lay 1.2-fold (0.09 log units) below the measured number, within the range that was stated.
By their numbers in this assay, from the lowest: compounds 2, 1 and 3 (each within the scatter of the next).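

In this assay, replacing bromo by nitro on the aromatic carbon gives a 1.1-fold higher number from compound 2 to compound 3 (0.06 log units; within the scatter) and replacing methyl by nitro gives no change at the digits printed from compound 1 to compound 3 (within the scatter) on the same carbon. Even nitro, with 3 heavy atoms and 2 hydrogen-bond acceptors where bromo has 1 heavy atom and none, stays within the scatter of the other two compounds, so this position has not yet separated any of the three groups. No other measurement here bears on this result. From the compounds shown here alone, whether an amine, a carboxylic acid or a longer chain at this position would move the number beyond the scatter stays open.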